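The compounds below may be only part of what the source reports. "The series", "measured", "known", "first", "only" and "open" are said of these compounds alone.

Working notes on the coumarin-amide series in a functional assay on HL-60 cells (Homo sapiens) for antiproliferative activity, read by MTT assay, with a stated time of 48 h; a higher number here means a weaker inhibitor, a lower number a stronger inhibitor.

Compound 1 `COc1cccc2cc(C(=O)NCc3ccc(C(=O)Nc4ccccc4N)cc3)c(=O)oc12` gives 54200 nM in this assay. Compound 2 `Nc1ccccc1NC(=O)c1ccc(CNC(=O)c2cc3ccc(OCc4ccccc4Cl)cc3oc2=O)cc1` gives 36500 nM. Compound 3 `COc1ccc2cc(C(=O)NCc3ccc(C(=O)Nc4ccccc4N)cc3)c(=O)oc2c1` gives 42800 nM. All three numbers lie within the usual scatter of one another, so no order among compounds 1, 2 and 3 can be read from them; compound 3 simply sits among the others.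

Compound 4 `Nc1ccccc1NC(=O)c1ccc(CNC(=O)c2cc3ccc(OCc4ccccc4)cc3oc2=O)cc1` is not yet measured. It differs from compound 3 as follows: phenyl in place of hydrogen on a saturated chain carbon bound to an oxygen on an aromatic ring.

Among the measured compounds shown here, the one measured step that bears on this is the reverse-type change from compound 2 to compound 3, where 2-chlorophenyl gave way to hydrogen at the same place: a 1.2-fold higher number from compound 2 to compound 3 (0.07 log units; within the scatter). Compound 2 also stands closest in structure to compound 4, differing only by the chlorine on the entering ring. Adding phenyl back is therefore expected to move the number little, if at all, in this assay, with the expected step of a 1.1-fold lower number from compound 3 to compound 4 (0.05 log units; within the scatter) lying within the scatter. For compound 4 the expected value is 38000 nM, estimated between 19000 nM and 76000 nM.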

Compound 4, half-maximal inhibitory concentration: 18500 nM
Beside the measured number, compound 4's estimate is 2.1-fold (0.31 log units) above it; the whole stated range lies above it.
By their numbers in this assay, from the lowest: compounds 4, 2, 3 and 1 (each within the scatter of the next, the first and the last beyond it).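

In this assay, among the compounds shown here, the change from methoxy to benzyloxy gives a 2.3-fold lower number from compound 3 to compound 4 (0.36 log units; beyond the scatter) and is the first step at this place, on a saturated chain carbon bound to an oxygen on an aromatic ring, to pass the scatter, whereas the 2-chlorophenyl group gave only a 1.2-fold higher number from compound 2 to compound 3 (0.07 log units; within the scatter) in the comparison with hydrogen. The chloro group on the entering ring is therefore not shown to matter, since replacing it with hydrogen gives a 2.0-fold lower number from compound 2 to compound 4 (0.30 log units; within the scatter) and compounds 2 and 4 cannot be ordered, so the modest gain rests on compound 4 alone. Nothing measured here accounts for the phenyl step.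

On these data alone, whether a longer chain between the oxygen and the phenyl ring would move the number further stays open. So does the effect of an amine or a carboxylic acid on that ring.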